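Chloropurine series: loss of one chloro group

The compounds below may be only part of what the source reports. "The series", "measured", "known", "first", "only" and "open" are said of these compounds alone.

Three compounds with a shared purine-like core carry a chloromethyl-substituted benzyl arm. Compound 1 `ClCc1ccc(Cn2cnc3c(Cl)ncnc32)cc1` was tested in a functional assay on Hs-578T cells (Homo sapiens) for cytotoxicity, read by sulforhodamine B assay, with a stated time of 48 h; on this read-out higher numbers stand for lower toxicity in this test and lower numbers for higher toxicity in this test. In this assay compound 1 gives only a limit, > 100000 nM. Compound 3 `ClCc1ccccc1Cn1cnc2nc(Cl)nc(Cl)c21` likewise gives only a limit in this assay, > 100000 nM. Compound 2 `ClCc1cccc(Cn2cnc3nc(Cl)nc(Cl)c32)c1` has no number in this assay; the entry reads "not determined" (no result reported). So compound 2 stands nowhere on the scale yet, while the two values that do exist both sit at the limit of > 100000 nM in this assay, at which 2 of the 3 values shown sit, which is a limit of the assay and not a number.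

Compound 4 `ClCc1cccc(Cn2cnc3ncnc(Cl)c32)c1` is the next compound for this assay. Relative to compound 2 the change is hydrogen in place of chloro on an aromatic carbon.

No measured step exists between any two of these compounds, so the size of the step from compound 2 to compound 4 in this assay cannot be read from data; with compound 2 itself undetermined, no direction can be given either. The expectation rests on compound 1 with > 100000 nM and compound 3 with > 100000 nM, both at the limit. Compound 4 is therefore expected to report in this assay near 100000 nM, with a range from 30000 nM to 300000 nM, and most likely as a limit again.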

Compound 4, concentration lethal to 50% of the cells: 97700 nM
Compound 4: the middle estimate sits 1.0-fold (0.01 log units) above what was measured; the range from low to high includes it.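

No step can be read from the results in this assay: compound 2 has no single number there, while compound 4 gives 97700 nM. The compounds shown leave open what hydrogen in place of chloro, on the aromatic carbon between two ring nitrogen atoms, does to the read-out in this assay.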